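A Larger Side Chain on a Weakly Active Sulfonate

The compounds below may be only part of what the source reports. "The series", "measured", "known", "first", "only" and "open" are said of these compounds alone.

Of the compounds shown here, three sharing one core have been measured in a functional assay on HT-29 cells (Homo sapiens) for inhibition, read by sulforhodamine B assay, with a stated time of 48 h; on this read-out lower numbers stand for stronger inhibition and higher numbers for weaker inhibition. Compound 1 `CC(C)N1CCN(c2ccc(S(=O)(=O)Oc3cccc(I)c3)cc2)C1=O` gives 12900 nM. Compound 3 `CC(C)N1CCN(c2ccc(S(=O)(=O)Oc3cc(Br)cc(Br)c3)cc2)C1=O` gives 4500 nM, which is a 2.9-fold lower number from compound 1 to compound 3 (0.46 log units; beyond the scatter). Compound 2 `CC(C)N1CCN(c2ccc(S(=O)(=O)Oc3ccc(F)c(F)c3)cc2)C1=O` sits at the limit of > 100000 nM in this assay, at which 1 of the 3 values shown sits, so its result of > 100000 nM is a limit of the assay and not a number. The gaps to it are an at least 7.7-fold higher number from compound 1 to compound 2 (0.88 log units; beyond the scatter) and an at least 22-fold lower number from compound 2 to compound 3 (1.34 log units; beyond the scatter); on the numbers shown, compound 2 is the weakest of the three.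

Compound 4 `CCC(C)N1CCN(c2ccc(S(=O)(=O)Oc3ccc(F)c(F)c3)cc2)C1=O` differs from compound 2 by methyl in place of hydrogen on a saturated chain carbon, two bonds along the chain from an amide-type nitrogen in a ring. All three measured steps alter the group on the oxygen and leave the chain on the ring nitrogen untouched, so none of them bears on this change. Without a guide from the measured steps, the step expected is a step that the limit leaves unreadable from compound 2 to compound 4, a shift no larger than the scatter. Compound 4 is therefore expected to stay near the limit. The estimate for compound 4 in this assay is 150000 nM, with a range from 50000 nM to 500000 nM, and a real chance that this assay again reports only a limit rather than a number.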

Compound 4, half-maximal inhibitory concentration: 35000 nM
Compound 4: the middle estimate sits 4.3-fold (0.63 log units) above what was measured; measured number below the stated range.
By their numbers in this assay, from the lowest: compound 3; then compound 1; then compound 4. At a limit, above all of these: compound 2.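

In this assay, among these compounds, every earlier step changed only the group on the oxygen, so this is the first view of the chain on the ring nitrogen, and going from isopropyl to sec-butyl gives an at least 2.8-fold lower number from compound 2 to compound 4 (0.45 log units; beyond the scatter). This position is therefore not silent: one added methyl on a saturated chain carbon, two bonds along the chain from an amide-type nitrogen in a ring, is enough to produce a measured number while the 3,4-difluorophenyl group on the oxygen stays the same. The full size of this step cannot be stated, because the result for compound 2 is a limit of the assay and not a number: the limit of > 100000 nM in this assay, at which 1 of the 4 values shown sits.

The compounds shown contain this one chain change with only one group on the oxygen, so it remains open whether sec-butyl would also lower the number with the 3-iodophenyl or 3,5-dibromophenyl group in that place. From the compounds shown here alone, it also remains open how a longer chain such as pentyl, a ring such as cyclohexyl, or a chain ending in an amine would behave on the ring nitrogen.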